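The source may hold more compounds than are shown below. What is called first, only, known or untested is meant among the compounds shown, and "the series" means these compounds.

Working notes on the series. Among the measured compounds shown here, compound 3 `CCN(CC)S(=O)(=O)c1ccc(NC(=O)C(C)(O)C(F)(F)F)cc1` is the only member with a number in an assay on a protein complex (Cavia porcellus) with sulfonylurea receptors; K-ATP channels (Homo sapiens) as the target; on this read-out lower numbers stand for stronger inhibition and higher numbers for weaker inhibition: compound 3 gives 810 nM. Compound 1 `CCC(C)N(C(C)CC)S(=O)(=O)c1ccc(NC(=O)C(C)(O)C(F)(F)F)cc1` gives only a limit of the assay in this assay, > 30000 nM. Compound 2 `CC(O)(C(=O)Nc1ccc(S(=O)(=O)N2CCNCC2)cc1)C(F)(F)F` likewise gives only a limit in this assay, > 30000 nM. Both sit at the limit of > 30000 nM in this assay, at which 2 of the 3 values shown sit, so the steps of an at least 37-fold lower number from compound 1 to compound 3 (1.56 log units; beyond the scatter) and an at least 37-fold lower number from compound 2 to compound 3 (1.56 log units; beyond the scatter) are readable only as lower bounds, yet both show that the group on the sulfonyl sulfur moves the number strongly. Compound 4 `CC(O)(C(=O)Nc1ccc([C@H](O)c2ccccc2)cc1)C(F)(F)F` differs from compound 3 by hydroxy(phenyl)methyl in place of diethylsulfamoyl on an aromatic carbon. For the measured compounds named here, no measured step removes the sulfonamide itself; the two measured steps only show that this part of the molecule is sensitive. The expected step is a 7.4-fold higher number from compound 3 to compound 4 (0.87 log units; beyond the scatter), toward weaker inhibition, with wide uncertainty. Compound 4 is estimated in this assay at 6000 nM, between 600 nM and 30000 nM.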

Compound 4, half-maximal inhibitory concentration: > 30000 nM
Compound 4 gave a limit, no number (the forecaster's own chance of this, stated with the estimate: 40%); middle value at least 5.0-fold (0.69 log units) from the limit.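

Earlier steps varied only the group on the sulfonyl sulfur, whereas this change removes the sulfonamide itself and brings, in this assay, an at least 37-fold higher number from compound 3 to compound 4 (1.56 log units; beyond the scatter). Compound 4 gives only a limit of the assay, not a number, so this step is a lower bound: the limit of > 30000 nM in this assay, at which 3 of the 4 values shown sit.

Among the compounds shown, only the diethylsulfamoyl group of compound 3 gives a number at this aromatic carbon. Still open, on these data alone, is whether a carboxylic acid or a nitrile at this carbon would give a number, and whether a pyrrolidine on the sulfonyl sulfur would lower it.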